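A few compounds are considered here, and "the series" means these few. Any claim that something is new, unique, unknown or untested is made for them only; others in the source may bear on it.

Measured compounds:
compound 1 `COc1cc(-c2nnc3n2NC(c2ccco2)C(C(=O)c2ccccc2C)S3)cc(OC)c1OC` with 69900 nM;
compound 2 `COc1cc(-c2nnc3n2NC(c2ccco2)C(C(=O)c2ccccc2F)S3)cc(OC)c1OC` with 94800 nM.

In a functional assay on MCF7 cells (Homo sapiens) for cytotoxicity, read by MTT assay, with a stated time of 48 h (a lower number here means a stronger inhibitor, a higher number a weaker inhibitor), compound 1 and compound 2 lie within the scatter of each other, as the step of a 1.4-fold higher number from compound 1 to compound 2 (0.13 log units; within the scatter) shows. Compound 3 `COc1cc(-c2nnc3n2NC(c2ccco2)C(C(=O)c2ccco2)S3)cc(OC)c1OC` differs from compound 1 by furan-2-yl in place of 2-methylphenyl on a carbonyl carbon. Within the data shown here, no measured step covers this replacement; the only step on record changes a substituent on the 2-methylphenyl and stays within the scatter. Compound 3 is therefore expected to stay near compound 1, with a step of a 1.1-fold higher number from compound 1 to compound 3 (0.06 log units; within the scatter). Compound 3 is estimated at 80000 nM, between 25000 nM and 250000 nM.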

Compound 3, half-maximal inhibitory concentration: > 100000 nM
Compound 3 gave a limit, no number (the forecaster's own chance of this, stated with the estimate: 15%); at least 1.2-fold (0.09 log units) between middle value and limit.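

Compound 3 replaces the whole aromatic ring on the carbonyl carbon, not just a substituent on it. In this assay this gives an at least 1.4-fold higher number from compound 1 to compound 3 (0.15 log units; that floor lies within the scatter) and an at least 1.0-fold higher number from compound 2 to compound 3 (0.02 log units; that floor lies within the scatter), so neither step is shown to pass beyond the scatter. Compound 3 gives a limit and not a number, which leaves the true size of both steps unknown: the limit of > 100000 nM in this assay, at which 1 of the 3 values shown sits.

The compounds shown leave open whether an amine or a carboxylic acid on the carbonyl carbon, in place of the aromatic ring, would give a readable number.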